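The compounds below may be only part of what the source reports. "The series", "measured", "known", "first", "only" and "open" are said of these compounds alone.

Measured so far in a functional assay on PC-3 cells (Homo sapiens) for inhibition, read by MTT assay, with a stated time of 72 h, tested at 10 uM; on this read-out higher numbers stand for more inhibition of growth at the one concentration tested and lower numbers for less inhibition of growth:
- compound 1, `O=C(/C=C/c1ccc(Cl)c([N+](=O)[O-])c1)/C=C/c1ccccc1Oc1ncnc2ccc(Cl)cc12`: 62.5%
- compound 2, `O=C(/C=C/c1ccc(Oc2ncnc3ccc(Cl)cc23)cc1)/C=C/c1c(Cl)cccc1Cl`: 67.5%

Compound 2 and compound 1 differ in more than one place, so no single step is drawn between them; their two numbers lie within the usual scatter of each other, and on the numbers shown compound 2 cannot be told apart from compound 1 in this assay.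

Compound 3, `O=C(/C=C/c1ccc(Oc2ncnc3ccc(Cl)cc23)cc1)/C=C/c1ccc(Cl)c(Cl)c1`, has not been measured. It differs from compound 2 by 3,4-dichlorophenyl in place of 2,6-dichlorophenyl on a double-bonded chain carbon bound to a double-bonded chain carbon, with the same atoms joined differently. Going by the values given here, no measured pair isolates this kind of change, so its size in this assay is unknown. A step no larger than the scatter is expected, in no set direction, as a number 2.5 percentage points lower from compound 2 to compound 3 (within the scatter). Compound 3 is estimated to give 65%, in the range 45% to 85%, carried over from compound 2 with widened uncertainty.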

Compound 3, percent growth inhibition at one concentration: 33.5%
Estimate against measurement, compound 3: 31.5 percentage points above, and the stated range ends above it.
By their numbers in this assay, from the lowest: compound 3; then compounds 1 and 2 (each within the scatter of the next).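

In this assay, 3,4-dichlorophenyl in place of 2,6-dichlorophenyl on a double-bonded chain carbon bound to a double-bonded chain carbon gives a number 34 percentage points lower from compound 2 to compound 3 (beyond the scatter). The two groups carry the same atoms and the same counts, so this place in the series is sensitive to how the two chlorines are arranged, something the earlier pair, differing in more than one place, could not show. No measurement at hand gives a reason for the size of this step.

From the compounds shown here alone, it remains open whether one chlorine alone, or a methoxy or dimethylamino group in place of the chlorines on this phenyl ring, would read closer to compound 2 or to compound 3. Going by these compounds, whether the same exchange has a step of similar size on the core of compound 1 is also open.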